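This account rests on a few compounds, and the source may have more. Where it says the series, first, only, none or still open, it means among the compounds named here.

Compound 1 `CCn1cc(C(=O)O)c(=O)c2cc(F)c(N3CCN(C(=N)NS(=O)(=O)c4ccc(C)cc4)CC3)cc21`, in a functional assay on A549 cells (Homo sapiens) for antiproliferative activity, read by MTT assay, with a stated time of 72 h (on this read-out lower numbers stand for stronger inhibition and higher numbers for weaker inhibition), compound 1 gives 71 nM.
Compound 2 `N=C(NS(=O)(=O)c1ccc(C(F)(F)F)cc1)N1CCN(c2cc3c(cc2F)c(=O)c(C(=O)O)cn3C2CC2)CC1`, in this assay compound 2 gives 71 nM.
Compound 3 `CCn1cc(C(=O)O)c(=O)c2cc(F)c(N3CCN(C(=N)NS(=O)(=O)c4ccccc4C(F)(F)F)CC3)cc21`, in this assay compound 3 gives 71 nM.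

Compound 3 stands level with compounds 1 and 2 at the digits shown, with no step to either beyond the scatter. Compound 4 `CCn1cc(C(=O)O)c(=O)c2cc(F)c(N3CCN(C(=N)NS(=O)(=O)c4ccc(C(F)(F)F)cc4)CC3)cc21` differs from compound 3 in one place: 4-(trifluoromethyl)phenyl in place of 2-(trifluoromethyl)phenyl on a sulfonyl sulfur. Within the data shown here, the one measured step at the sulfonyl sulfur, no change at the digits printed from compound 1 to compound 3 (within the scatter), stayed within the scatter, and compound 2, which carries the same 4-(trifluoromethyl)phenyl on its own core, shows the same value as compound 3. No step beyond the scatter is therefore expected for this change. For compound 4 the expected step is no change at the digits printed from compound 3 to compound 4 (within the scatter), and the estimate is 71 nM, between 35 nM and 145 nM.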

Compound 4, half-maximal inhibitory concentration: 71 nM
Compound 4: middle estimate and measured number agree at the digits printed, within the range that was stated.
By their numbers in this assay, from the lowest: compounds 1, 2, 3 and 4 (each within the scatter of the next).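

In this assay, 4-(trifluoromethyl)phenyl in place of 2-(trifluoromethyl)phenyl on the sulfonyl sulfur gives no change at the digits printed from compound 3 to compound 4 (within the scatter), so this position shows no response to where the trifluoromethyl sits on the ring. Ethyl in place of cyclopropyl on the aromatic nitrogen gives no change at the digits printed from compound 2 to compound 4 (within the scatter), and trifluoromethyl in place of methyl on an aromatic carbon gives no change at the digits printed from compound 1 to compound 4 (within the scatter) as well. No evidence is available to explain these results.

Still open, from the compounds shown here alone, is whether any group on the sulfonyl sulfur can shift the value beyond the scatter, such as a phenyl carrying an amine or a longer alkyl chain in place of the aromatic ring.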